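The source may hold more compounds than are shown below. What is called first, only, known or untested is meant among the compounds shown, and "the series" means these compounds.

In a functional assay (mast cells) for inhibition, with Rattus norvegicus as the target (a lower number here means that less compound is needed, a higher number that more compound is needed for the effect), compound 3 (`CC1CC/C(=N\Nc2ccc(-c3ccccc3)cc2)c2ncc(C(=O)O)c(=O)n21`) gives 4400 nM and sits between the other two measured compounds: compound 2 (`CC(C)c1ccc(N/N=C2\CCC(C)n3c2ncc(C(=O)O)c3=O)cc1`) gives 1200 nM and compound 1 (`CC1CC/C(=N\Nc2ccc(C(=O)O)cc2)c2ncc(C(=O)O)c(=O)n21`) gives 1000000 nM on the same core. Compound 4 (`CC1CC/C(=N\Nc2ccc(CC(=O)O)cc2)c2ncc(C(=O)O)c(=O)n21`) has carboxymethyl in place of phenyl on an aromatic carbon. Compound 1 carries carboxy at this place, and the steps of a 230-fold lower number from compound 1 to compound 3 (2.36 log units; beyond the scatter) and an 830-fold lower number from compound 1 to compound 2 (2.92 log units; beyond the scatter) were both large, whereas a 3.7-fold higher number from compound 2 to compound 3 (0.56 log units; beyond the scatter) was modest. Carboxymethyl also ends in carboxy, so a large step to a higher number is expected in this assay but one that may stop short of compound 1. The expected change is a 34-fold higher number from compound 3 to compound 4 (1.53 log units; beyond the scatter) in this estimate. Compound 4 is estimated at 150000 nM (expected range 20000 nM to 1000000 nM).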

Compound 4, half-maximal effective concentration: 3400 nM
Beside the measured number, compound 4's estimate is 44-fold (1.64 log units) above it; measured number outside the range, below it.
By their numbers in this assay, from the lowest: compound 2; then compounds 4 and 3 (each within the scatter of the next); then compound 1.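

In this assay, carboxymethyl at this place, para to a large group, does not behave like carboxy (a 290-fold lower number from compound 1 to compound 4 (2.47 log units; beyond the scatter)). Set against phenyl, it shows no difference that can be read (a 1.3-fold lower number from compound 3 to compound 4 (0.11 log units; within the scatter)), and against isopropyl only a modest gap remains (a 2.8-fold higher number from compound 2 to compound 4 (0.45 log units; beyond the scatter)). A terminal carboxy at this place therefore does not by itself bring the high number of compound 1, and phenyl's aromatic ring is not needed to reach the level of compound 3.

From the compounds shown here alone, whether a longer chain ending in carboxy, or an amine, would hold this level remains open. Nothing here explains the gap between carboxy and carboxymethyl.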